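Swapping a Hydroxyphenyl for a Dichlorophenyl on the Core

A few compounds are considered here, and "the series" means these few. Any claim that something is new, unique, unknown or untested is made for them only; others in the source may bear on it.

Going by the values given here, compound 2 `COc1cc(/C=C/C(=O)C2=C(/C=C/c3ccc(O)c(OC)c3)NC(=S)NC2c2ccccc2O)ccc1O` gives 86.3% in a functional assay, with a stated time of 20 min, tested at 50 uM (a higher number here means a stronger effect of the compound at the concentration tested, a lower number a weaker effect), the higher of the two numbers measured so far, while compound 1 `COc1cc(/C=C/C(=O)C2=C(/C=C/c3ccc(O)c(OC)c3)NC(=S)NC2c2ccccc2)ccc1O` gives 48%. Among the compounds with values here, the only measured step, a number 38.3 percentage points higher from compound 1 to compound 2 (beyond the scatter), came from putting a hydroxy in place of hydrogen on an aromatic carbon. Compound 3 `COc1cc(/C=C/C(=O)C2=C(/C=C/c3ccc(O)c(OC)c3)NC(=S)NC2c2c(Cl)cccc2Cl)ccc1O` has not been measured yet; it differs from compound 2 by 2,6-dichlorophenyl in place of 2-hydroxyphenyl on a saturated ring carbon. Since this change takes away the hydroxy whose arrival gave the large measured step, a fall is expected, estimated as a number 36.3 percentage points lower from compound 2 to compound 3 (beyond the scatter). Compound 3 is therefore expected to give 50%, within a range from 25% to 75%.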

Compound 3, a percentage reported as activity, at one concentration (the size of the read-out at that concentration, not a potency): 50.2%
Beside the measured number, compound 3's estimate is 0.2 percentage points below it; the range from low to high includes it.
By their numbers in this assay, from the lowest: compounds 1 and 3 (each within the scatter of the next); then compound 2.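

In this assay, 2,6-dichlorophenyl does not replace what 2-hydroxyphenyl provides at this saturated ring carbon, giving a number 36.1 percentage points lower from compound 2 to compound 3 (beyond the scatter) in that swap. Set against the plain phenyl, the same group gives a number 2.2 percentage points higher from compound 1 to compound 3 (within the scatter) so the two chlorines leave the number unchanged, and among these compounds only 2-hydroxyphenyl gives the high number. Nothing available explains this difference. Still open, going by these compounds, is whether a methoxy or an amine in place of that hydroxy would keep the high number. A single chlorine on the phenyl also remains to be compared.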